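The source may hold more compounds than are shown below. What is called first, only, known or untested is meant among the compounds shown, and "the series" means these compounds.

Measured in a functional assay on NCI-H460 cells (Homo sapiens) for inhibition, read by MTT assay, with a stated time of 72 h; a higher number here means a weaker inhibitor, a lower number a stronger inhibitor:
- Compound 1 `COc1cc(NC(C)CCCNC(=O)Nc2cccc(F)c2)c2ncccc2c1`: 24000 nM
- Compound 2 `COc1cc(NC(C)CCCNC(=O)Nc2cccc(Cl)c2)c2ncccc2c1`: 37000 nM
- Compound 3 `COc1cc(NC(C)CCCNC(=O)NNC(=O)Nc2ccc(F)cc2)c2ncccc2c1`: > 100000 nM

Compound 3 stands at > 100000 nM in this assay, which is a limit of the assay and not a number. Compound 4 `COc1cc(NC(C)CCCNC(=O)NNC(=O)Nc2ccc(C(F)(F)F)cc2)c2ncccc2c1` differs from it in one place: trifluoromethyl in place of fluoro on an aromatic carbon. The nearest measured precedent is another swap on an aromatic carbon, chloro in place of fluoro, with a 1.5-fold higher number from compound 1 to compound 2 (0.19 log units; within the scatter). That step lies within the scatter, but it belongs to a pair without the ((4-fluorophenyl)carbamoyl)amino group of compound 3. The other two steps, an at least 4.1-fold higher number from compound 1 to compound 3 (0.61 log units; beyond the scatter) and an at least 2.7-fold higher number from compound 2 to compound 3 (0.43 log units; beyond the scatter), are both beyond the scatter, but they exchange the group on the amide-type nitrogen and so do not test this swap. Only a small step is therefore expected, towards a lower number if there is one, and the limit hides its true size. The expected step is an at least 1.4-fold lower number from compound 3 to compound 4 (0.15 log units; that floor lies within the scatter). Compound 4 is estimated at 70000 nM, with an expected range of 25000 nM to 130000 nM.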

Compound 4, half-maximal inhibitory concentration: 12000 nM
Compound 4: middle estimate off by 5.8-fold (0.77 log units), on the high side; the whole stated range lies above it.
By their numbers in this assay, from the lowest: compounds 4, 1 and 2 (each within the scatter of the next, the first and the last beyond it). At a limit, above all of these: compound 3.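

Swapping fluoro for trifluoromethyl on this aromatic carbon, para to a large group, gives an at least 8.3-fold lower number from compound 3 to compound 4 (0.92 log units; beyond the scatter), so in this assay this position responds clearly to the change. Among the compounds shown here, the only earlier swap on an aromatic carbon, in the pair without the ((4-fluorophenyl)carbamoyl)amino group, gave a 1.5-fold higher number from compound 1 to compound 2 (0.19 log units; within the scatter), which showed no such response. The true size of the new step stays hidden, as compound 3 sits at a limit of the assay and not at a number: the limit of > 100000 nM in this assay, at which 1 of the 4 values shown sits.

The compounds shown leave open whether chloro, methyl or a nitrile on the same carbon would move the number as trifluoromethyl does. They also leave open whether trifluoromethyl would give a similar step in compounds 1 and 2, which lack the ((4-fluorophenyl)carbamoyl)amino group.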